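The source may hold more compounds than are shown below. What is called first, only, known or untested is meant among the compounds shown, and "the series" means these compounds.

The study follows a small set of compounds built on one shared core. Compound 1, `C=C1C[C@]23C[C@@]1(O)CC[C@H]2c1ccc(O)c(C)c1[C@@H]3Cn1cc(-c2ccc(F)cc2)nn1`, is described in a functional assay on A549 cells (Homo sapiens) for cytotoxicity, read by MTT assay, with a stated time of 4 days (a higher number here means a weaker inhibitor, a lower number a stronger inhibitor), only by a limit, which for compound 1 reads > 20000 nM. Among the compounds with values here, compound 2, `C=C1C[C@]23C[C@@]1(O)CC[C@H]2c1cc(Br)c(O)c(C)c1[C@@H]3Cn1cc(-c2ccc(Cl)cc2)nn1`, is the one member of the set with an actual number: in this assay compound 2 gives 10500 nM. Since compound 1 contributes no number of its own, this single reading is where compound 2 stands among the numbers available. Within the data shown here, no pair of compounds measured so far differs in just one place, so no measured step can be stated; of compound 1 and compound 2 it can only be said that one sits at the limit of > 20000 nM in this assay, at which 1 of the 2 values shown sits, and the other carries a number.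

Compound 3, `C=C1C[C@]23C[C@@]1(O)CC[C@H]2c1ccc(O)c(C)c1[C@@H]3Cn1cc(-c2ccc(Cl)cc2)nn1`, is not yet measured. It is made from compound 2 by hydrogen in place of bromo on an aromatic carbon. Among the measured compounds shown here, with no measured step to lean on, the expectation rests on compound 1, which lacks the bromo and sits at its limit of > 20000 nM. The step from compound 2 to compound 3 is therefore expected to be a loss of potency, a 1.5-fold higher number from compound 2 to compound 3 (0.18 log units; within the scatter), modest and possibly within the scatter. For compound 3 the estimate in this assay is 16000 nM, with a range from 6000 nM to 40000 nM.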

Compound 3, half-maximal inhibitory concentration: > 20000 nM
Compound 3 gave a limit, no number (the forecaster's own chance of this, stated with the estimate: 35%); middle value at least 1.2-fold (0.09 log units) away from the limit.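

In this assay, within the data shown here, hydrogen in place of bromo on the aromatic carbon ortho to a hydroxy group gives an at least 1.9-fold higher number from compound 2 to compound 3 (0.27 log units; that floor lies within the scatter), the only measured step at this position. Among these compounds, this is a floor and not a size, so the result does not establish an effect of the bromo beyond the scatter, though it leaves compound 2, the one compound carrying the bromo, as the only one with a number. Compound 1 and compound 3, the two without the bromo, both give a limit and not a number: the limit of > 20000 nM in this assay, at which 2 of the 3 values shown sit.

The step from compound 1 to compound 3, chloro in place of fluoro, cannot be read, so the compounds shown do not order those two halogens. Also open, going by these compounds, is how far the loss of the bromo really reaches, and whether a chloro, a methyl, an amine or a carboxylic acid on that aromatic carbon would give a number in this assay, or whether the bromo would do the same alongside the fluoro of compound 1.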